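From chloro to fluoro on the 2,4-dichlorobenzyl group

A few compounds are considered here, and "the series" means these few. Any claim that something is new, unique, unknown or untested is made for them only; others in the source may bear on it.

- Compound 1 `OC[C@H]1O[C@@H](n2cnc3c(NCc4ccccc4Cl)ncnc32)[C@H](O)[C@@H]1O`: 14500 nM
- Compound 2 `Cc1cccc(CNc2ncnc3c2ncn3[C@@H]2O[C@H](CO)[C@@H](O)[C@H]2O)c1`: 19100 nM
- Compound 3 `OC[C@H]1O[C@@H](n2cnc3c(NCc4ccc(Cl)cc4Cl)ncnc32)[C@H](O)[C@@H]1O`: 86700 nM

These values come from a functional assay on CCRF-CEM cells (Homo sapiens) for antiproliferative activity, with a stated time of 72 h; on this read-out lower numbers stand for stronger inhibition and higher numbers for weaker inhibition. Compound 3 has the highest number of the three, so it is the weakest here, and its steps to both others lie beyond the scatter. Compound 4 `OC[C@H]1O[C@@H](n2cnc3c(NCc4ccc(F)cc4Cl)ncnc32)[C@H](O)[C@@H]1O` differs from it in one group: fluoro in place of chloro on an aromatic carbon. This puts fluoro in place of chloro on an aromatic carbon, turning 2,4-dichlorobenzyl into 2-chloro-4-fluorobenzyl. Among the measured compounds shown here, no measured step makes this swap. The closest evidence is a 6.0-fold higher number from compound 1 to compound 3 (0.78 log units; beyond the scatter), where chloro took the place of hydrogen. The wider change a 4.5-fold higher number from compound 2 to compound 3 (0.66 log units; beyond the scatter) also ends at compound 3. Compound 4 lacks that added chloro but keeps a group in its place, so a partial return towards compound 1 is expected. The expected step is a 2.4-fold lower number from compound 3 to compound 4 (0.38 log units; beyond the scatter). The estimated value for compound 4 is 36000 nM, with an expected range of 13000 nM to 95000 nM.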

Compound 4, half-maximal inhibitory concentration: 20900 nM
The estimate for compound 4 lay 1.7-fold (0.24 log units) above the measured number, and the stated range covers the measured number.
By their numbers in this assay, from the lowest: compounds 1, 2 and 4 (each within the scatter of the next); then compound 3.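

Swapping chloro for fluoro on this aromatic carbon gives a 4.1-fold lower number from compound 3 to compound 4 (0.62 log units; beyond the scatter) in this assay, so a group at this place does not by itself bring the higher number seen with chloro. Fluoro in place of hydrogen gives a 1.4-fold higher number from compound 1 to compound 4 (0.16 log units; within the scatter) and the change of the whole aryl group gives a 1.1-fold higher number from compound 2 to compound 4 (0.04 log units; within the scatter), so compound 4 cannot be told apart from compound 1 or compound 2. Nothing shown here explains the gap between chloro and fluoro. On these data alone, whether bromo or methoxy on this carbon would follow chloro or fluoro remains open.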